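This account rests on a few compounds, and the source may have more. Where it says the series, first, only, none or still open, it means among the compounds named here.

Compound 1 `Cn1c(-c2cccc(Cl)c2)cnc1NC(=O)c1ccc(F)cc1` in a toxicity assay on THP-1 cells (Homo sapiens) for inhibition (a lower number here means that less compound is tolerated, a higher number that more compound is tolerated), gives > 50000 nM, which is a limit of the assay rather than a number.
Compound 2 `Cn1c(-c2cccc(F)c2)cnc1NC(=O)c1ccc(F)cc1` in this assay gives 58000 nM.
Compound 3 `Cn1c(-c2ccccc2Cl)cnc1NC(=O)c1ccc(F)cc1` in this assay gives > 50000 nM, again a limit of the assay and not a number.

Compound 3 therefore stands at the top edge of what this assay can report, and it is not alone there: the limit of > 50000 nM in this assay, at which 2 of the 3 values shown sit. The three measured steps are a step that the limit leaves unreadable from compound 1 to compound 2, a step that the two limits leave unreadable from compound 1 to compound 3 and a step that the limit leaves unreadable from compound 2 to compound 3; none of them can be read in size, since at least one end of each rests on a limit. What the three values do show is that every measured compound, whether it carries chloro or fluoro on the pendant ring and wherever that halogen sits, is tolerated up to the limit or close to it.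

Compound 4 `Cn1c(-c2ccc(Br)cc2)cnc1NC(=O)c1ccc(F)cc1` is the next compound to be measured in this assay. It differs from compound 3 as follows: 4-bromophenyl in place of 2-chlorophenyl on an aromatic carbon. Among the measured compounds shown here, no measured step speaks to swapping one halophenyl ring for another in a readable way, so no shift beyond the scatter is expected, and the step from compound 3 to compound 4 is estimated as a step that the limit leaves unreadable from compound 3 to compound 4. Compound 4 is accordingly expected to give about 60000 nM, within a range from 25000 nM to 150000 nM, quite possibly again only as a limit.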

Compound 4, half-maximal cytotoxic concentration: 46000 nM
For compound 4 the middle estimate is 1.3-fold (0.12 log units) above the measured one; the measured number falls inside the stated range.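

Among the compounds shown here, at this aromatic carbon, next to the ring nitrogen, 4-bromophenyl gives the first comparison between two halophenyl groups that can be read as a number, a 1.3-fold lower number from compound 2 to compound 4 (0.10 log units; within the scatter). Compound 1 and compound 3 rest on limits of the assay, so only floors can be read against them, an at least 1.0-fold lower number from compound 3 to compound 4 (0.03 log units; that floor lies within the scatter) and an at least 1.0-fold lower number from compound 1 to compound 4 (0.03 log units; that floor lies within the scatter). A different halogen in a different place on this ring thus produces no change that stands out from the scatter, and the measured numbers stay close to the top edge of what this assay can report: the limit of > 50000 nM in this assay, at which 2 of the 4 values shown sit.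

As far as these compounds go, all four compounds carry a halophenyl group at this carbon, so it remains open whether the same tolerance would hold with an amine or a carboxylic acid on that ring, or with a longer chain in its place. From the compounds shown here alone, the amide and its fluorinated ring are the same throughout, and the true values behind the two limits are unknown, so any real difference between the chlorophenyl compounds and compound 4 also stays open.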